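This account rests on a few compounds, and the source may have more. Where it says the series, first, only, none or still open, it means among the compounds named here.

Measured in a functional assay for antagonist activity at Neuropeptide Y receptor type 5 (Homo sapiens); a lower number here means a stronger inhibitor, a higher number a weaker inhibitor:

- compound 1 `Cc1cccc(-c2ccc(NC[C@H]3CC[C@]4(CC3)CN(c3cccnn3)C(=O)O4)nc2)n1`: 0.251 nM
- compound 2 `O=C1O[C@]2(CC[C@H](CNc3cnn(-c4ccccc4F)c3)CC2)CN1c1cncnc1`: 0.0398 nM
- compound 3 `O=C1O[C@]2(CC[C@H](CNc3ccc(-c4nccs4)cn3)CC2)CN1c1ccccn1`: 0.126 nM

Among these three numbers compound 1 stands highest. The nearest is compound 3, whose number lies within the scatter of compound 1, so the two cannot be ordered. Compound 2, built on a different arrangement of the shared core, gives a number whose gap to compound 1 lies beyond the scatter.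

Compound 4 `O=C1O[C@]2(CC[C@H](CNc3ccc(-c4ncccc4F)cn3)CC2)CN1c1cccnn1` differs from compound 1 in one place: 3-fluoropyridin-2-yl in place of 6-methylpyridin-2-yl on an aromatic carbon. Within the data shown here, no pair among the measured compounds isolates this exchange, so its effect in this assay is unknown from the data. The group that leaves and the group that enters are of the same size and carry the same count of donors and acceptors, and compound 3, with a different ring at that place, gives a number within the scatter of compound 1. The step is therefore expected to be a 1.3-fold lower number from compound 1 to compound 4 (0.10 log units; within the scatter), that is, no change beyond the scatter in either direction. Compound 4 is estimated to give 0.2 nM, with a range from 0.06 nM to 0.7 nM.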

Compound 4, inhibition constant: 0.316 nM
For compound 4 the middle estimate is 1.6-fold (0.20 log units) below the measured one; low and high end bracket the measured number.
By their numbers in this assay, from the lowest: compound 2; then compounds 3, 1 and 4 (each within the scatter of the next, the first and the last beyond it).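

In this assay, among these compounds, 3-fluoropyridin-2-yl in place of 6-methylpyridin-2-yl gives a 1.3-fold higher number from compound 1 to compound 4 (0.10 log units; within the scatter) and so provides the first pair of compounds that differ in one place. On this aromatic carbon, para to a large group, the two groups cannot be told apart in this read-out, since the step lies within the scatter. No measurement at hand ties this result to any property of either group.

The compounds shown leave open whether a group of another kind on this carbon, such as a carboxylic acid or an amine, would produce a step beyond the scatter. They also leave open whether the same exchange would give a similar step where the rest of the molecule differs.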